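The source may report more compounds than this note shows. Statements on the series, on what has been measured and on what is new or still open speak of the compounds shown alone.

In a functional assay on HCT-116 cells (Homo sapiens) for antiproliferative activity, read by MTT assay, with a stated time of 24 h; a lower number here means a stronger inhibitor, a higher number a weaker inhibitor:
compound 1 `C#CCOc1ccc2c(=O)c(-c3cc(OC)c(OC)cc3OC)coc2c1`: 8050 nM
compound 2 `COc1cc(OC)c(-c2coc3cc(OCc4ccccc4C#N)ccc3c2=O)cc1OC`: > 10000 nM, a limit of the assay and not a number
compound 3 `COc1cc(OC)c(-c2coc3cc(OCc4cccc(F)c4)ccc3c2=O)cc1OC`: 4920 nM

Compound 3 sits level with compound 1 within the scatter, as a 1.6-fold lower number from compound 1 to compound 3 (0.21 log units; within the scatter) shows. Compound 2 offers only a limit for comparison, so its position relative to the other two is open on the high side.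

Compound 4 `COc1cc(OC)c(-c2coc3cc(OCc4ccccc4Cl)ccc3c2=O)cc1OC` carries 2-chlorophenyl in place of 3-fluorophenyl on a saturated chain carbon bound to an oxygen on an aromatic ring. Among the measured compounds shown here, all the measured steps change the group at this same place. Besides the step above, there is an at least 1.2-fold higher number from compound 1 to compound 2 (0.09 log units; that floor lies within the scatter), and neither it nor any other step is shown to exceed the scatter.

The closest guide to the entering group is the 2-cyanophenyl of compound 2, with an at least 2.0-fold lower number from compound 2 to compound 3 (0.30 log units; that floor lies within the scatter). That points weakly towards a higher number in this assay for a group named in the same way, but it rests on a single compound and a limit. Only a small shift is therefore expected, not one beyond the scatter, and the estimated step is a 1.2-fold higher number from compound 3 to compound 4 (0.09 log units; within the scatter).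

For compound 4 the expected value is 6000 nM, with an estimated range of 2800 nM to 10000 nM.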

Compound 4, half-maximal inhibitory concentration: 2450 nM
Compound 4: middle estimate off by 2.4-fold (0.39 log units), on the high side; measured number outside the range, below it.
By their numbers in this assay, from the lowest: compounds 4, 3 and 1 (each within the scatter of the next, the first and the last beyond it). At a limit, above all of these: compound 2.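

In this assay, among the compounds shown here, the place on a saturated chain carbon bound to an oxygen on an aromatic ring now yields steps beyond the scatter, which no earlier pair showed: a 3.3-fold lower number from compound 1 to compound 4 (0.52 log units; beyond the scatter) for 2-chlorophenyl in place of ethynyl, and an at least 4.0-fold lower number from compound 2 to compound 4 (0.61 log units; beyond the scatter) for chloro in place of cyano on an aromatic carbon. The direct change from 3-fluorophenyl to 2-chlorophenyl does not separate the two compounds, with a 2.0-fold lower number from compound 3 to compound 4 (0.30 log units; within the scatter), so the separation from the ethynyl compound is firm only for the 2-chlorophenyl group. Compound 2 stands at a limit of the assay and not at a number, so its step to the chloro compound gives only a floor: the limit of > 10000 nM in this assay, at which 1 of the 4 values shown sits.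

In the pair of 3-fluorophenyl and 2-chlorophenyl, the halogen and its place on the ring change together, so the compounds shown do not tell these two changes apart. On these data alone, how an unsubstituted benzyl group, or a benzyl group carrying an amine or a carboxylic acid, would read in this assay also remains open.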